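Aryl swap on the piperazine amide: compound 4 expected

The compounds below may be only part of what the source reports. "The series", "measured", "known", "first", "only" and "open" are said of these compounds alone.

Measured so far:
compound 1 `CCC(C(=O)N1CCN(c2ccc(Cl)cc2)CC1)N1C(=O)CCC1=O` — 0%
compound 2 `CC(C(=O)N1CCN(c2ccc(Cl)cc2)CC1)N1C(=O)CCC1=O` — 100%
compound 3 `CCC(C(=O)N1CCN(c2cccc(C(F)(F)F)c2)CC1)N1C(=O)CCC1=O` — 75%

In a functional assay on the whole organism (strain Swiss) with Mus musculus as the target, in the maximal electroshock model, with a stated time of 0.25 h, at a dose of 300 mg/kg by the intraperitoneal route (a higher number here means a stronger effect of the compound at the dose given, a lower number a weaker effect), compound 2 gives 100%, the highest of the three numbers, with compound 3 the nearest at 75% and compound 1 the furthest at 0%. Among the compounds with values here, the one single-place step measured, a number 100 percentage points higher from compound 1 to compound 2 (beyond the scatter), shows that the chain at the carbon bearing the succinimide ring decides much here.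

Compound 4 `Cc1cccc(N2CCN(C(=O)C(C)N3C(=O)CCC3=O)CC2)c1` is the next target. It differs from compound 2 as follows: 3-methylphenyl in place of 4-chlorophenyl on an amine nitrogen in a ring. Within the data shown here, no measured step changes the aryl group alone, so the size of this step is not directly anchored. Compound 1 and compound 3 carry different aryl groups on the same ethyl-bearing core; compound 1 gives 0% and compound 3 gives 75%, and the two values show that the aryl group can move the read-out widely. Compound 2 sits at the top of the scale, so an expected step of a number 20 percentage points lower from compound 2 to compound 4 (beyond the scatter), downward or none beyond the scatter, seems most likely. Compound 4 is therefore estimated at 80%, within 40% to 100%.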

Compound 4, a percentage reported as activity, at one dose (the size of the read-out at that dose, not a potency): 100%
Beside the measured number, compound 4's estimate is 20 percentage points below it, and the stated range covers the measured number.
By their numbers in this assay, from the lowest: compound 1; then compound 3; then compounds 2 and 4 (each within the scatter of the next).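

In this assay, within the data shown here, the aryl exchange gives no change at the digits printed from compound 2 to compound 4 (within the scatter), the first reading of a change in this place alone on the core of compound 2. On that core, the chlorine of 4-chlorophenyl is not needed for the read-out at this dose, since compound 4, with the all-carbon 3-methylphenyl on the amine nitrogen, gives 100%; as a single-dose read-out, this says nothing on potency, and any difference between the two aryl groups at lower doses stays unseen. No independent measurement bears on this result.

Still open, as far as these compounds go, is whether 3-methylphenyl would hold the read-out on the ethyl-bearing core of compound 1. Also open, from the compounds shown here alone, is how a methoxy group or a nitrile on the phenyl ring, or a pyridine ring in its place, would fare on the core of compound 2.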